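Swapping 3,4-Dichlorophenyl for Phenyl on Compound 1

This account rests on a few compounds, and the source may have more. Where it says the series, first, only, none or still open, it means among the compounds named here.

For the measured compounds named here, in a functional assay on CCRF-CEM cells (Homo sapiens) for cytotoxicity (a higher number here means a weaker inhibitor, a lower number a stronger inhibitor), compound 1 `O=C(/C=C/C(=O)N1C/C(=C\c2ccc([N+](=O)[O-])cc2)C(=O)/C(=C/c2ccc([N+](=O)[O-])cc2)C1)Nc1ccc(Cl)c(Cl)c1` gives 380 nM, the lower of the two numbers so far. Compound 2 `Cc1ccc(NC(=O)/C=C/C(=O)N2C/C(=C\c3ccccc3)C(=O)/C(=C/c3ccccc3)C2)cc1C` gives 7100 nM, a gap beyond the scatter. Compound 3 `O=C(/C=C/C(=O)N1C/C(=C\c2ccc([N+](=O)[O-])cc2)C(=O)/C(=C/c2ccc([N+](=O)[O-])cc2)C1)Nc1ccccc1` keeps the core of compound 1 but has phenyl in place of 3,4-dichlorophenyl on an amide-type nitrogen. Going by the values given here, no measured pair shows this change alone. A modest move toward a higher number in this assay is expected, perhaps little beyond the scatter. The expected step is a 1.6-fold higher number from compound 1 to compound 3 (0.20 log units; within the scatter). For compound 3 the estimated value is 600 nM, within an expected range of 200 nM to 2000 nM.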

Compound 3, half-maximal inhibitory concentration: 370 nM
Beside the measured number, compound 3's estimate is 1.6-fold (0.21 log units) above it; low and high end bracket the measured number.
By their numbers in this assay, from the lowest: compounds 3 and 1 (each within the scatter of the next); then compound 2.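

In this assay putting phenyl in place of 3,4-dichlorophenyl on the amide-type nitrogen gives a 1.0-fold lower number from compound 1 to compound 3 (0.01 log units; within the scatter) and so, on the core of compound 1, this assay does not separate the two groups. The earlier compounds shown here could not show this, as compound 1 and compound 2 differ in more than one place. Nothing measured here offers an explanation for this result. As far as these compounds go, what a carboxylic acid or an amine on that phenyl, or a longer chain in its place, would do remains open. Also open, from the compounds shown here alone, is whether this swap gives the same result on a different core.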